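This account rests on a few compounds, and the source may have more. Where it says the series, first, only, none or still open, it means among the compounds named here.

Working notes on the series. Compound 1 `COc1cccc(-c2c(C)nn(-c3nc(-c4ccc(Cl)c(Cl)c4)c(SC(C)C)s3)c2C(=O)O)c1` gives 14000 nM in a functional assay on BJAB cells (Homo sapiens) for antiproliferative activity, with a stated time of 4 days; a lower number here means that less compound is needed, a higher number that more compound is needed for the effect. Compound 2 `CCOc1ncccc1-c1c(C)nn(-c2nc(-c3ccc(Cl)c(Cl)c3)c(SC(C)C)s2)c1C(=O)O` gives 11000 nM in this assay, and compound 3 `COc1ccccc1-c1c(C)nn(-c2nc(-c3ccc(Cl)c(Cl)c3)c(SC(C)C)s2)c1C(=O)O` gives 14700 nM. All three numbers sit within the scatter of one another: a 1.1-fold higher number from compound 1 to compound 3 (0.02 log units; within the scatter) and a 1.3-fold higher number from compound 2 to compound 3 (0.13 log units; within the scatter), so compound 3 is not set apart from compound 1 or compound 2 on these numbers.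

Compound 4 `Cc1nn(-c2nc(-c3ccc(Cl)c(Cl)c3)c(SC(C)C)s2)c(C(=O)O)c1-c1ccccc1C(F)(F)F` differs from compound 3 in one place: trifluoromethyl in place of methoxy on an aromatic carbon. Among the compounds with values here, no measured step swaps these two groups. The steps that come nearest touch the same aromatic substituent: a 1.3-fold lower number from compound 1 to compound 2 (0.10 log units; within the scatter), a 1.1-fold higher number from compound 1 to compound 3 (0.02 log units; within the scatter), a 1.3-fold higher number from compound 2 to compound 3 (0.13 log units; within the scatter). Each stayed within the scatter, so three exchanges of the whole aromatic substituent left the read-out unmoved, and nothing here points to a shift in either direction for the exchange of methoxy for trifluoromethyl. Compound 4 is therefore expected near compound 3, with a 1.1-fold lower number from compound 3 to compound 4 (0.02 log units; within the scatter) expected to lie within the scatter. The estimate for compound 4 is 14000 nM, expected between 5000 nM and 40000 nM.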

Compound 4, half-maximal effective concentration: 5200 nM
The estimate for compound 4 lay 2.7-fold (0.43 log units) above the measured number; measured number inside the range.
By their numbers in this assay, from the lowest: compound 4; then compounds 2, 1 and 3 (each within the scatter of the next).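

Within the data shown here, this position is not silent after all: trifluoromethyl in place of methoxy, ortho to a large group, gives a 2.8-fold lower number from compound 3 to compound 4 (0.45 log units; beyond the scatter) in this assay, the first step to leave the scatter. The exchanges of the whole aromatic substituent that end in 2-(trifluoromethyl)phenyl read the same way, with a 2.1-fold lower number from compound 2 to compound 4 (0.33 log units; beyond the scatter) and a 2.7-fold lower number from compound 1 to compound 4 (0.43 log units; beyond the scatter), so all three steps to this group are modest but beyond the scatter, while the three steps among the alkoxy-bearing substituents stayed within it. No available evidence bears on what lies behind this shift.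

Still open, on these data alone, is whether the lower number is specific to trifluoromethyl or would also come with a chlorine, a methyl or a nitrile on the same aromatic carbon. The compounds shown also leave open whether trifluoromethyl would give the same step on a pyridine ring like that of compound 2.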